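Carboxy to hydroxymethyl at the chain end

This account rests on a few compounds, and the source may have more. Where it says the series, first, only, none or still open, it means among the compounds named here.

Three compounds have so far been measured in a functional assay on PC-3 cells (Homo sapiens) for inhibition, read by sulforhodamine B assay, with a stated time of 48 h; on this read-out lower numbers stand for stronger inhibition of growth and higher numbers for weaker inhibition of growth:
Compound 1 `COC1=C[C@H](O)[C@H](C/C=C(\C)CC/C=C(\C)CCC=C(C)C)[C@@H](C)C1=O` gives > 30000 nM.
Compound 2 `COC1=C(OC)[C@H](OC(C)=O)[C@H](C/C=C(\C)CC/C=C(\C)C[C@H](O)/C=C(\C)C(=O)O)[C@@H](C)C1=O` gives > 30000 nM.
Compound 3 `COC1=C(OC)[C@H](O)[C@H](C/C=C(\C)CC/C=C(\C)CCC=C(C)C)[C@@H](C)C1=O` gives 13500 nM.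

The values of compound 1 and compound 2 are limits of the assay, not numbers. Compound 2 thus sits at the limit of > 30000 nM in this assay, at which 2 of the 3 values shown sit, and only compound 3 returns a number in this assay. Going by the values given here, the single measured step, an at least 2.2-fold lower number from compound 1 to compound 3 (0.34 log units; beyond the scatter), concerns a methoxy on a ring carbon and says nothing about the chain.

Compound 4 `COC1=C(OC)[C@H](OC(C)=O)[C@H](C/C=C(\C)CC/C=C(\C)C[C@H](O)/C=C(\C)CO)[C@@H](C)C1=O` differs from compound 2 by hydroxymethyl in place of carboxy on a double-bonded chain carbon bound to a double-bonded chain carbon and a saturated chain carbon. Among the compounds with values here, no measured pair shows this exchange, so no step size for it can be read from the data. Compound 4 is therefore expected to stay near where compound 2 stands, and the step of an at least 1.2-fold lower number from compound 2 to compound 4 (0.07 log units; that floor lies within the scatter) is expected to remain within the scatter. Compound 4 is estimated at 25000 nM, with a range from 7000 nM to 60000 nM, and a fair chance that this assay again reports only a limit.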

Compound 4, concentration for 50% growth inhibition: > 30000 nM
Compound 4 gave a limit, no number (the forecaster's own chance of this, stated with the estimate: 55%); middle value at least 1.2-fold (0.07 log units) from the limit.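

Compound 2 and compound 4 both return only a limit in this assay, so no step can be read between them: the limit of > 30000 nM in this assay, at which 3 of the 4 values shown sit.

The compounds shown leave open whether carboxy or hydroxymethyl at this place on the chain makes any difference to growth inhibition in this assay.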